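A few compounds are considered here, and "the series" means these few. Any claim that something is new, unique, unknown or untested is made for them only; others in the source may bear on it.

Measured so far in an assay on CHO cells for displacement of a labelled ligand from Neuronal acetylcholine receptor; alpha3/alpha6/beta2/beta3 (Homo sapiens), read by scintillation counting; on this read-out lower numbers stand for stronger inhibition and higher numbers for weaker inhibition:
- compound 1 `CC(=O)N1CC2CC(C1)N2` gives 610 nM
- compound 2 `O=C([C@@H]1C[C@@H]1F)N1CC2CC(C1)N2` gives 55 nM
- compound 3 `O=C([C@H]1C[C@@H]1F)N1CC2CC(C1)N2` gives 490 nM

Compound 3 stands second highest of the three numbers. Against compound 1 the step is a 1.2-fold lower number from compound 1 to compound 3 (0.10 log units; within the scatter); against compound 2 it is an 8.9-fold higher number from compound 2 to compound 3 (0.95 log units; beyond the scatter), a difference that goes with the fact that one of compounds 2 and 3 is drawn with a defined configuration and the other without, at the place where they differ.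

Compound 4 `C[C@H]1C[C@@H]1C(=O)N1CC2CC(C1)N2` differs from compound 3 by methyl in place of fluoro on a saturated ring carbon. Within the data shown here, no measured step exchanges fluoro for methyl on this ring; the nearest steps, a 1.2-fold lower number from compound 1 to compound 3 (0.10 log units; within the scatter) and an 8.9-fold higher number from compound 2 to compound 3 (0.95 log units; beyond the scatter), concern the whole 2-fluorocyclopropyl group or its drawn configuration, not this substituent. Among the measured compounds shown here, with no direct precedent, the expected step in this assay is a 1.1-fold lower number from compound 3 to compound 4 (0.04 log units; within the scatter), that is, no change beyond the scatter. The estimate for compound 4 is therefore 450 nM, within 150 nM to 1400 nM.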

Compound 4, inhibition constant: 310 nM
For compound 4 the middle estimate is 1.5-fold (0.16 log units) above the measured one; measured number inside the range.
By their numbers in this assay, from the lowest: compound 2; then compounds 4, 3 and 1 (each within the scatter of the next).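

Methyl in place of fluoro on this saturated ring carbon gives the first direct read of that substituent, and the step stays within the scatter (a 1.6-fold lower number from compound 3 to compound 4 (0.20 log units; within the scatter)). The 2-methylcyclopropyl group also stays within the scatter of the methyl on the carbonyl carbon (a 2.0-fold lower number from compound 1 to compound 4 (0.29 log units; within the scatter)), while compound 2 remains clearly apart (a 5.6-fold higher number from compound 2 to compound 4 (0.75 log units; beyond the scatter)). Nothing measured here accounts for these steps.

Among these compounds, open is how the 2-methylcyclopropyl group behaves in the other drawn configuration, the one matching compound 2. Also open, on these data alone, is whether chloro or hydroxyl on this ring carbon would differ from fluoro or methyl.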